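This account rests on a few compounds, and the source may have more. Where it says the series, first, only, none or still open, it means among the compounds named here.

Measured in a functional assay on K562 cells (Homo sapiens) for antiproliferative activity, with a stated time of 72 h; on this read-out lower numbers stand for stronger inhibition and higher numbers for weaker inhibition:
- Compound 1 `OC[C@H]1O[C@@H](n2cnc3c(NCc4ccc(Cl)cc4)ncnc32)[C@H](O)[C@@H]1O`: 218000 nM
- Compound 2 `COc1cc(CNc2ncnc3c2ncn3[C@@H]2O[C@H](CO)[C@@H](O)[C@H]2O)cc(OC)c1`: > 166000 nM
- Compound 3 `OC[C@H]1O[C@@H](n2cnc3c(NCc4ccc(F)cc4F)ncnc32)[C@H](O)[C@@H]1O`: 9600 nM

The entry for compound 2, > 166000 nM, is a limit of the assay and not a number. Of the two readable numbers, compound 3 has the lower, 9600 nM.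

Compound 4 `Cc1ccc(O)c(CNc2ncnc3c2ncn3[C@@H]2O[C@H](CO)[C@@H](O)[C@H]2O)c1` is still unmeasured. It differs from compound 3 in one place, on a saturated chain carbon bound to a nitrogen on an aromatic ring: 2-hydroxy-5-methylphenyl in place of 2,4-difluorophenyl on a saturated chain carbon bound to a nitrogen on an aromatic ring. In words, 2-hydroxy-5-methylphenyl replaces 2,4-difluorophenyl.

Two measured steps changed the group at this same place, and both are large: a 23-fold lower number from compound 1 to compound 3 (1.36 log units; beyond the scatter), and an at least 17-fold lower number from compound 2 to compound 3 (1.23 log units; beyond the scatter). So far, only the 2,4-difluorophenyl group of compound 3 gives a number this low, and moving away from it has cost much in both cases. Within the data shown here, with only three compounds this is a thin basis, but a similar loss seems likely here.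

The expected change in this assay is a 6.3-fold higher number from compound 3 to compound 4 (0.80 log units; beyond the scatter), towards weaker inhibition. For compound 4 the estimated value is 60000 nM, with an expected range of 10000 nM to 250000 nM.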

Compound 4, half-maximal inhibitory concentration: 16500 nM
The estimate for compound 4 lay 3.6-fold (0.56 log units) above the measured number; the measured number falls inside the stated range.
By their numbers in this assay, from the lowest: compounds 3 and 4 (each within the scatter of the next); then compound 1.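

In this assay, among these compounds, the 2,4-difluorophenyl group of compound 3 is no longer the only group at this place that gives a low number: putting 2-hydroxy-5-methylphenyl there gives a 1.7-fold higher number from compound 3 to compound 4 (0.24 log units; within the scatter). So a group with a hydrogen-bond donor and acceptor and no fluorine also fits here, and it stands clear of the 4-chlorophenyl and 3,5-dimethoxyphenyl groups, with a 13-fold lower number from compound 1 to compound 4 (1.12 log units; beyond the scatter) and an at least 10-fold lower number from compound 2 to compound 4 (1.00 log units; beyond the scatter). The second of these steps rests on compound 2, whose entry is a limit and not a number: the limit of > 166000 nM in this assay, at which 1 of the 4 values shown sits.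

Compounds 3 and 4 share no substituent on the ring, so the compounds shown cannot tell which substituents matter. Going by these compounds, how a plain phenyl, a pyridine ring or a longer chain between the ring and the nitrogen would behave also stays open.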